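The source may hold more compounds than are shown below. What is called first, only, known or untested is meant among the compounds shown, and "the series" means these compounds.

In a functional assay on HT-29 cells (Homo sapiens) for antiproliferative activity, read by MTT assay, with a stated time of 72 h (on this read-out lower numbers stand for stronger inhibition and higher numbers for weaker inhibition), compound 1 `COc1cc(-c2nccn2C(C)C)cc(OC)c1OC` gives > 100000 nM, which is a limit of the assay and not a number. Compound 2 `COc1cc(OC)cc(-n2ccnc2-c2cc(OC)c(OC)c(OC)c2)c1` does give a number, 74500 nM. Compound 3 `COc1cc(-c2nccn2-c2ccc(F)cc2)cc(OC)c1OC` keeps the core of compound 1 but carries 4-fluorophenyl in place of isopropyl on an aromatic nitrogen. Within the data shown here, no measured step exists yet to guide the expectation. Among the measured compounds shown here, with compound 2 at 74500 nM as the only number so far, a modest move towards stronger inhibition is expected, and the expected step is an at least 3.3-fold lower number from compound 1 to compound 3 (0.52 log units; beyond the scatter). For compound 3 the estimated value is 30000 nM, with an expected range from 5000 nM to 100000 nM.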

Compound 3, half-maximal inhibitory concentration: 29300 nM
Compound 3: middle estimate off by 1.0-fold (0.01 log units), on the high side; the range from low to high includes it.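

In this assay, among these compounds, the aromatic nitrogen proves sensitive to its substituent, with 4-fluorophenyl in place of isopropyl giving an at least 3.4-fold lower number from compound 1 to compound 3 (0.53 log units; beyond the scatter) and a measurable number for the first time. The step is a minimum, not a full size, because compound 1 stands at a limit of the assay: the limit of > 100000 nM in this assay, at which 1 of the 3 values shown sits.

Whether the fluorine contributes anything remains open, as plain phenyl is not among the compounds shown. Also open, going by these compounds, is how a phenyl ring carrying an amine or a carboxylic acid would behave at this nitrogen.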